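A few compounds are considered here, and "the series" means these few. Any claim that something is new, unique, unknown or untested is made for them only; others in the source may bear on it.

Of the compounds shown here, three of one series have been tested in a functional assay on MX1 cells (Homo sapiens) for inhibition, read by MTT assay, with a stated time of 120 h; a higher number here means a weaker inhibitor, a lower number a stronger inhibitor. Compound 1 `CC(NC(=O)CCc1ccc(NC(=O)Nc2ccc(Cl)c(C(F)(F)F)c2)cc1)c1ccccc1` carries a (1-phenylethyl)amino group on a carbonyl carbon whose other neighbour is a saturated chain carbon. In this assay compound 1 reaches only > 50000 nM, which is a limit of the measurement and not a number. Compound 3 `CC1CN(C(=O)CCc2ccc(NC(=O)Nc3ccc(Cl)c(C(F)(F)F)c3)cc2)CC(C)O1` arises from compound 1 by 2,6-dimethylmorpholin-4-yl in place of (1-phenylethyl)amino on a carbonyl carbon. In this assay compound 3 likewise stops at > 50000 nM, again a limit rather than a number. The step that the two limits leave unreadable from compound 1 to compound 3 therefore cannot be read, because both ends sit at the limit of > 50000 nM in this assay, at which 2 of the 3 values shown sit.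

Compound 2 `CC(NC(=O)c1ccc(-c2ccc(NC(=O)Nc3cc(C(F)(F)F)ccc3Cl)cc2)cc1)c1ccccc1` has a different core; how its core differs from that of compound 1 is not broken down here. In this assay, among the compounds with values here, compound 2 gives 17700 nM, the only actual number among the three.

Compound 4 `CC1CN(C(=O)c2ccc(-c3ccc(NC(=O)Nc4cc(C(F)(F)F)ccc4Cl)cc3)cc2)CC(C)O1` is not yet measured. It differs from compound 2 by 2,6-dimethylmorpholin-4-yl in place of (1-phenylethyl)amino on a carbonyl carbon. This is the same kind of change as that from compound 1 to compound 3, but not the same: in compound 1 the carbonyl carbon's other neighbour is a saturated chain carbon, whereas in compound 2 it is an aromatic carbon. Because the step that the two limits leave unreadable from compound 1 to compound 3 gives no readable size, the expectation for compound 4 rests mainly on the value of compound 2, 17700 nM. The analogous change in the other core, from compound 1 to compound 3, gave no readable step. The step from compound 2 to compound 4 is expected to be a 1.7-fold higher number from compound 2 to compound 4 (0.23 log units; within the scatter). Compound 4 is expected to give 30000 nM, with a plausible range from 8000 nM to 60000 nM.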

Compound 4, half-maximal inhibitory concentration: > 50000 nM
Compound 4: a limit, no number (the forecaster's own chance of this, stated with the estimate: 45%); middle value at least 1.6-fold (0.22 log units) from the limit.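

In this assay, putting 2,6-dimethylmorpholin-4-yl in place of (1-phenylethyl)amino, on a carbonyl carbon whose other neighbour is an aromatic carbon, gives an at least 2.8-fold higher number from compound 2 to compound 4 (0.45 log units; beyond the scatter), so in the core of compound 2 this change goes with a weaker inhibitor. Compound 4 stops at > 50000 nM, which is a limit of the assay and not a number, so the step has a lower end but no known full size. Whether the change acts alike in the two cores cannot be said, because the matching step in the core of compound 1 cannot be read, with both of its ends at the same limit that compound 4 reaches: the limit of > 50000 nM in this assay, at which 3 of the 4 values shown sit.

The compounds shown leave open which part of the swap goes with the weaker result, since the leaving and entering groups differ in several ways at once, and a plain benzylamino group or an unsubstituted morpholin-4-yl group on the same carbonyl carbon could help separate them. Within the data shown here, with compound 2 as the only compound giving an actual number, the series also offers no second readable step against which to test how well this change carries from one core to another.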